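The compounds below may be only part of what the source reports. "The series", "measured", "known", "first", "only" and "open" are said of these compounds alone.

Measured compounds in the series:

- Compound 1, `CCN1CCN(c2cccc3c2C(=O)N([C@H](CCCNS(=O)(=O)c2cn(C)c(C)n2)c2ccc(OC)c(OC)c2)C3=O)CC1`: 140 nM
- Compound 2, `COc1ccc([C@@H](CCCN(C)S(=O)(=O)c2cccs2)N2Cc3c(cccc3N3CCN(C4CCC4)CC3)C2=O)cc1OC`: 4 nM
- Compound 3, `CCN1CCN(c2cccc3c2CN([C@H](CCCNC(=O)c2cccs2)c2ccc(OC)c(OC)c2)C3=O)CC1`: 7 nM

All three were run in a functional assay on CHO-K1 cells for antagonist activity at Urotensin-2 receptor (Rattus norvegicus), read by FLIPR and calcium flux, with a stated time of 1 h; on this read-out lower numbers stand for stronger inhibition and higher numbers for weaker inhibition. Compound 2 shows the lowest of the three numbers. Its gap to compound 3 lies within the usual scatter, so the two cannot be ranked against each other; its gap to compound 1 lies well beyond the scatter.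

Compound 4, `COc1ccc([C@@H](CCCN(C)S(=O)(=O)c2cccs2)N2Cc3c(cccc3N3CCNCC3)C2=O)cc1OC`, has not yet been measured. It keeps the core and the sulfonamide side chain of compound 2 and differs in one place: hydrogen in place of cyclobutyl on an amine nitrogen in a ring. Going by the values given here, no pair of measured compounds shows a single change of this kind, so the direction and size of the step cannot be read from the measured values. The three measured compounds all carry an alkyl group on that ring nitrogen, and nothing here shows what the free ring nitrogen does. A modest weakening is expected, with the step from compound 2 to compound 4 estimated as a 3.8-fold higher number from compound 2 to compound 4 (0.57 log units; beyond the scatter) in this assay. Compound 4 is thus expected to give 15 nM, in a range of 4 nM to 60 nM.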

Compound 4, half-maximal inhibitory concentration: 39 nM
Compound 4: the middle estimate sits 2.6-fold (0.41 log units) below what was measured, within the range that was stated.
By their numbers in this assay, from the lowest: compounds 2 and 3 (each within the scatter of the next); then compound 4; then compound 1.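

In this assay, going by these compounds alone, the change from cyclobutyl to hydrogen on the amine nitrogen of the ring gives the first single-change step at this position, a 9.8-fold higher number from compound 2 to compound 4 (0.99 log units; beyond the scatter). The group on this nitrogen therefore matters within this pair, although with the free ring nitrogen compound 4 still gives 39 nM. Nothing in the data gives a reason for this step.

From the compounds shown here alone, it remains open where a methyl, isopropyl or acetyl group on this ring nitrogen would fall relative to hydrogen and cyclobutyl in this assay. Going by these compounds, it is also open whether replacing the ethyl group on the same nitrogen with hydrogen would produce a step of similar size in compound 3, with its thiophene carboxamide side chain, or in compound 1, with its different core.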